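The source may hold more compounds than are shown below. What is called first, only, known or untested is meant among the compounds shown, and "the series" means these compounds.

In a functional assay on KB cells (Homo sapiens) for cytotoxicity (a lower number here means a stronger inhibitor, a higher number a weaker inhibitor), compound 2 `N#Cc1cn(Cc2ccccc2)c2ncnc(N)c12` gives > 100000 nM, which is a limit and not a number. Compound 1 `CCOCn1cc(C#N)c2c(N)ncnc21` gives > 100000 nM, also a limit. Compound 3 `CC(C)(C)c1ccc(Cn2cc(C#N)c3c(N)ncnc32)cc1` gives 3000 nM. The step that the two limits leave unreadable from compound 1 to compound 2 says little, whereas the step of an at least 33-fold lower number from compound 2 to compound 3 (1.52 log units; beyond the scatter) came with tert-butyl in place of hydrogen on an aromatic carbon. Compound 4 `C=CCn1cc(C#N)c2c(N)ncnc21` has vinyl in place of phenyl on a saturated chain carbon bound to an aromatic nitrogen. It carries no tert-butyl, and most of this small set sits at one ceiling: the limit of > 100000 nM in this assay, at which 2 of the 3 values shown sit. No drop in the number is therefore expected, so the expected step is a number no higher from compound 2 to compound 4 (the limit leaves the size open). The estimated value for compound 4 is 100000 nM, within an expected range of 30000 nM to 300000 nM.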

Compound 4, half-maximal inhibitory concentration: > 100000 nM
Compound 4 gave a limit, no number; the forecaster's own chance of this, stated with the estimate: 85%; the middle value lies on the limit itself.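

Compound 4 gives a limit and not a number, as do compound 1 and compound 2, so no step among these three can be read: the limit of > 100000 nM in this assay, at which 3 of the 4 values shown sit.

The compounds shown leave open how far compound 1, compound 2 and compound 4 truly differ, and whether vinyl, phenyl or ethoxy matters at this place.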